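The compounds below may be only part of what the source reports. "The series", "measured", "known", "first", "only" and "open" are said of these compounds alone.

Compound 3 `O=C(Nc1c(C(O)(C(F)(F)F)C(F)(F)F)ccc2ccccc12)c1cccc(Br)c1` gives 80 nM in an assay on LtK cells with ATP-sensitive inward rectifier potassium channel 11 (Homo sapiens) as the target (a higher number here means that more compound is needed for the effect, a lower number that less compound is needed), the lowest number among those measured. Compound 2 `O=C(CCc1ccccc1)Nc1c(C(O)(C(F)(F)F)C(F)(F)F)ccc2ccccc12` gives 1750 nM in this assay, and the step of a 22-fold lower number from compound 2 to compound 3 (1.34 log units; beyond the scatter) separates them. Compound 1 `CCCC(C)C(=O)Nc1c(C(O)(C(F)(F)F)C(F)(F)F)ccc2ccccc12` reaches only a limit in this assay, > 10000 nM (the limit of > 10000 nM in this assay, at which 1 of the 3 values shown sits). The steps of an at least 5.7-fold lower number from compound 1 to compound 2 (0.75 log units; beyond the scatter) and an at least 120-fold lower number from compound 1 to compound 3 (2.09 log units; beyond the scatter) both concern the group on the carbonyl carbon. Compound 4 `O=C(Nc1c(C(O)(C(F)(F)F)C(F)(F)F)ccc2ccccc12)c1ccc(I)cc1` differs from compound 3 in one place: 4-iodophenyl in place of 3-bromophenyl on a carbonyl carbon. No measured step exchanges one halogenated phenyl for another, so nothing shown speaks for a change beyond the scatter. Compound 4 is therefore expected to give 80 nM in this assay, between 25 nM and 250 nM. The expected step is no change at the digits printed from compound 3 to compound 4 (within the scatter).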

Compound 4, half-maximal effective concentration: 154 nM
Compound 4: middle estimate off by 1.9-fold (0.28 log units), on the low side, within the range that was stated.
By their numbers in this assay, from the lowest: compounds 3 and 4 (each within the scatter of the next); then compound 2. At a limit, above all of these: compound 1.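

In this assay, a halogenated phenyl on the carbonyl carbon can be exchanged for another with no change beyond the scatter, a 1.9-fold higher number from compound 3 to compound 4 (0.28 log units; within the scatter), even though the halogen and its ring position differ together. The advantage over the non-aromatic and phenethyl groups therefore extends beyond compound 3, with an 11-fold lower number from compound 2 to compound 4 (1.06 log units; beyond the scatter) and an at least 64-fold lower number from compound 1 to compound 4 (1.81 log units; beyond the scatter). That last step is open-ended, as compound 1 stands at a limit: the limit of > 10000 nM in this assay, at which 1 of the 4 values shown sits.

The compounds shown leave open how an unsubstituted phenyl, 3-iodophenyl or 4-bromophenyl would read. They also leave open whether a pyridine ring could replace the phenyl.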